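Swapping an anilino group for piperidine on two isomeric cores

The source may report more compounds than this note shows. Statements on the series, on what has been measured and on what is new or still open speak of the compounds shown alone.

The study concerns a small set of fused tetracyclic quinone-like compounds tested in a functional assay on MGC-803 cells (Homo sapiens) for inhibition, read by sulforhodamine B assay; on this read-out higher numbers stand for weaker inhibition and lower numbers for stronger inhibition. Compound 1, `O=C1C(Nc2ccc(I)cc2)=CC(=O)c2c1nc1n2[C@H]2OC[C@@H](O)[C@H]2OC1`, carries a (4-iodophenyl)amino group and gives 2150 nM in this assay. Compound 3, `O=C1C=C(Nc2ccc(I)cc2)C(=O)c2c1nc1n2[C@H]2OC[C@@H](O)[C@H]2OC1`, has the same atoms joined differently; the difference between the two cores is not broken down here. In this assay compound 3 gives 1400 nM, a value within the usual scatter of that of compound 1.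

Compound 2, `O=C1C(N2CCCCC2)=CC(=O)c2c1nc1n2[C@H]2OC[C@@H](O)[C@H]2OC1`, differs from compound 1 by piperidin-1-yl in place of (4-iodophenyl)amino on a double-bonded ring carbon. For compound 2 this assay reports only a limit, > 4000 nM, so the step from compound 1 is known only as a floor: an at least 1.8-fold higher number from compound 1 to compound 2 (0.26 log units; that floor lies within the scatter). The same threshold recurs in the data as the limit of > 4000 nM in this assay, at which 1 of the 3 values shown sits.

Compound 4, `O=C1C=C(N2CCCCC2)C(=O)c2c1nc1n2[C@H]2OC[C@@H](O)[C@H]2OC1`, is not yet measured. It differs from compound 3 by piperidin-1-yl in place of (4-iodophenyl)amino on a double-bonded ring carbon, the same change as that from compound 1 to compound 2, made at the same kind of place on the core of compound 3. Given that compound 2 reached the limit of this assay, compound 4 is expected to sit weaker than compound 3 as well, with an estimated step of a 4.3-fold higher number from compound 3 to compound 4 (0.63 log units; beyond the scatter), resting on the step from compound 1 to compound 2. The estimated value for compound 4 in this assay is 6000 nM, with a likely range from 2500 nM to 15000 nM, and a real chance that only a limit is reported.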

Compound 4, half-maximal inhibitory concentration: > 8000 nM
Compound 4: a limit, no number; the forecaster's own chance of this, stated with the estimate: 60%; middle value at least 1.3-fold (0.12 log units) from the limit.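

On the core of compound 3, putting piperidin-1-yl in place of (4-iodophenyl)amino gives an at least 5.7-fold higher number from compound 3 to compound 4 (0.75 log units; beyond the scatter) in this assay, and this step is a floor, since compound 4 is reported only as a limit. Set beside the earlier step, the change points the same way on both cores, although only the floor on the core of compound 3 clears the scatter: the same change on two cores in this assay, an at least 1.8-fold higher number (0.26 log units; that floor lies within the scatter) from compound 1 to compound 2 and an at least 5.7-fold higher number (0.75 log units; beyond the scatter) from compound 3 to compound 4; the limit leaves it open whether they differ. This shows that the change carries over to the core of compound 3 as a clear weakening, and that the direction on the core of compound 1 is compatible with it, but it does not show that the step has the same size on both cores, or how large either step really is.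

The compounds shown leave open which part of the (4-iodophenyl)amino group matters, as piperidin-1-yl differs from it in the iodine, the aromatic ring and the amine hydrogen all at once. A plain phenylamino group, a cyclohexylamino group or a morpholin-4-yl group on either core would begin to separate these parts, and would show whether other amines also end at a limit.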